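Replacing the side chain of compound 2

The compounds below may be only part of what the source reports. "The series", "measured", "known", "first", "only" and "open" are said of these compounds alone.

Compound 1 `O=C(Nc1ccccn1)c1cccc(Nc2ncc(F)c(Nc3ccc(F)cc3)n2)c1` gives 20000 nM
Compound 2 `CN(C)CC(=O)Nc1cccc(Nc2ncc(F)c(Nc3ccc(F)cc3)n2)c1` gives 1260 nM

Both values come from a functional assay on KB cells (Homo sapiens) for antiproliferative activity, read by sulforhodamine B assay, with a stated time of 3 days; a higher number here means a weaker inhibitor of growth, a lower number a stronger inhibitor of growth. Going by the values given here, compound 2 holds the lower of the two numbers, and the only measured step is a 16-fold lower number from compound 1 to compound 2 (1.20 log units; beyond the scatter). That step put (((dimethylamino)methyl)carbonyl)amino in place of (pyridin-2-yl)carbamoyl on an aromatic carbon.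

Compound 3 `O=C(NCCO)c1cccc(Nc2ncc(F)c(Nc3ccc(F)cc3)n2)c1` carries (2-hydroxyethyl)carbamoyl in place of (((dimethylamino)methyl)carbonyl)amino on an aromatic carbon, the difference being ((2-hydroxyethyl)carbamoyl in place of (((dimethylamino)methyl)carbonyl)amino on an aromatic carbon). It gives up the group of compound 2 and returns to a carbamoyl group, as in compound 1, but without the pyridin-2-yl. Among the compounds with values here, the one measured step, a 16-fold lower number from compound 1 to compound 2 (1.20 log units; beyond the scatter), therefore bears only in part, and a partial move back towards a higher number is expected. The expected step is a 4.0-fold higher number from compound 2 to compound 3 (0.60 log units; beyond the scatter). For compound 3 the estimated value is 5000 nM, with an expected range of 1500 nM to 20000 nM.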

Compound 3, concentration for 50% growth inhibition: 12400 nM
Compound 3: middle estimate off by 2.5-fold (0.39 log units), on the low side; measured number inside the range.
By their numbers in this assay, from the lowest: compound 2; then compounds 3 and 1 (each within the scatter of the next).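

In this assay, (2-hydroxyethyl)carbamoyl in place of (((dimethylamino)methyl)carbonyl)amino on the aromatic carbon gives a 9.8-fold higher number from compound 2 to compound 3 (0.99 log units; beyond the scatter). On the amide-type nitrogen of the carbamoyl group, 2-hydroxyethyl in place of pyridin-2-yl gives a 1.6-fold lower number from compound 1 to compound 3 (0.21 log units; within the scatter), so these two substituents cannot be told apart in this assay. Among these three compounds, the two carbamoyl compounds therefore stand together, while compound 2, with its (((dimethylamino)methyl)carbonyl)amino group, holds the lowest number. Nothing available gives a reason for either step. As far as these compounds go, what stays open is whether the lower number of compound 2 goes with its dimethylamino group or with the way its chain is joined to the aromatic ring. A carbamoyl chain ending in a dimethylamino group would separate the two.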